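A few compounds are considered here, and "the series" means these few. Any claim that something is new, unique, unknown or untested is made for them only; others in the source may bear on it.

Measured in a toxicity assay on MDCK cells (Canis lupus familiaris) for cytotoxicity, read by crystal violet staining, with a stated time of 48 h; on this read-out higher numbers stand for lower toxicity in this test and lower numbers for higher toxicity in this test:
- compound 1 `Cc1ccc2[nH]c(=O)c(CN(Cc3ccc(F)cc3)Cc3ccc(C(C)(C)C)cc3)cc2c1`: > 27000 nM
- compound 2 `CCCc1ccc2[nH]c(=O)c(CN(Cc3ccc(F)cc3)Cc3ccc(C(C)(C)C)cc3)cc2c1`: 8400 nM
- compound 3 `Cc1ccc2[nH]c(=O)c(CN(Cc3ccc(F)cc3)Cc3ccc(-c4ccccc4)cc3)cc2c1`: > 5000 nM

Compound 1 stands at a limit, > 27000 nM, and not at a number. Compound 3 is also only a limit, > 5000 nM.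

Compound 4 `Cc1ccc2[nH]c(=O)c(CN(Cc3ccc(O)cc3)Cc3ccc(C(C)(C)C)cc3)cc2c1` carries hydroxy in place of fluoro on an aromatic carbon, para to a large group: hydroxy in place of fluoro on an aromatic carbon.

Two measured steps start from compound 1, and both lie elsewhere in the structure. The step of an at least 3.2-fold lower number from compound 1 to compound 2 (0.50 log units; beyond the scatter) comes with ethyl in place of hydrogen on a saturated chain carbon. The step that the two limits leave unreadable from compound 1 to compound 3 comes with phenyl in place of tert-butyl. Neither changes the fluoro group, so no step beyond the scatter is expected: an at least 1.0-fold lower number from compound 1 to compound 4 (0.03 log units; that floor lies within the scatter). The expected value for compound 4 is 25000 nM, with an estimated range of 8000 nM to 80000 nM.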

Compound 4, half-maximal cytotoxic concentration: 4900 nM
Estimate against measurement, compound 4: 5.1-fold (0.71 log units) above; measured number below the stated range.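

In this assay, hydroxy in place of fluoro on this aromatic carbon gives an at least 5.5-fold lower number from compound 1 to compound 4 (0.74 log units; beyond the scatter). The fluoro group stays unchanged in compound 2 and compound 3, so this step shows that the read-out also responds to a change at this position. The size is only a floor, because compound 1 stands at a limit and not at a number: the limit of > 27000 nM in this assay, at which 1 of the 4 values shown sits.

On these data alone, it remains open whether an amine or a methoxy group at the same place would give a similar step. Also open, as far as these compounds go, is whether the same change would hold alongside the propyl group of compound 2.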